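Acetoxymethyl enones: halogen swap on the aryl substituent

The compounds below may be only part of what the source reports. "The series", "measured", "known", "first", "only" and "open" are said of these compounds alone.

Measured so far:
- Compound 1 `CC(=O)OC/C(=C\C1CCCCC1)C(=O)c1ccccc1` — 19000 nM
- Compound 2 `CCC(/C=C(\COC(C)=O)C(=O)c1ccccc1)CC` — 77000 nM
- Compound 3 `CC(=O)OC/C(=C\c1ccccc1Br)C(=O)c1ccccc1` — 14000 nM

In a functional assay on SW1573 cells (Homo sapiens) for inhibition, read by sulforhodamine B assay, with a stated time of 48 h (a higher number here means a weaker inhibitor of growth, a lower number a stronger inhibitor of growth), compound 3 gives the lowest number of the three, yet compound 1 lies within the scatter of it, while the step of a 5.5-fold lower number from compound 2 to compound 3 (0.74 log units; beyond the scatter) is the only clear separation, matched by a 4.1-fold higher number from compound 1 to compound 2 (0.61 log units; beyond the scatter) and a 1.4-fold lower number from compound 1 to compound 3 (0.13 log units; within the scatter).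

Compound 4 `CC(=O)OC/C(=C\c1ccccc1F)C(=O)c1ccccc1` differs from compound 3 by fluoro in place of bromo on an aromatic carbon. Among the measured compounds shown here, no measured step swaps one halogen for another; the steps so far exchange the whole group on the double-bonded chain carbon, and the closest one, a 1.4-fold lower number from compound 1 to compound 3 (0.13 log units; within the scatter), is within the scatter. The expectation for a 1.1-fold higher number from compound 3 to compound 4 (0.06 log units; within the scatter) is therefore no step beyond the scatter. Compound 4 is estimated at 16000 nM, within 7000 nM to 40000 nM.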

Compound 4, concentration for 50% growth inhibition: 6100 nM
Compound 4: the middle estimate sits 2.6-fold (0.42 log units) above what was measured; measured number below the stated range.
By their numbers in this assay, from the lowest: compound 4; then compounds 3 and 1 (each within the scatter of the next); then compound 2.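

In this assay, among the compounds shown here, the choice of halogen on this aromatic carbon shows with a 2.3-fold lower number from compound 3 to compound 4 (0.36 log units; beyond the scatter) as the only step so far that swaps one halogen for another. Unlike 2-bromophenyl, which stays within the scatter of cyclohexyl, 2-fluorophenyl separates from both other groups, with a 3.1-fold lower number from compound 1 to compound 4 (0.49 log units; beyond the scatter) and with a 13-fold lower number from compound 2 to compound 4 (1.10 log units; beyond the scatter) in the series. Nothing available here bears on why fluoro and bromo differ.

Open, from the compounds shown here alone, is whether chloro, methoxy or an amine on the same aromatic carbon would extend this halogen difference. Also open, going by these compounds, is whether it survives when a carboxylic acid replaces the acetoxymethyl group.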